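Shortening the Chain on the Sulfur-Linked Arm

The compounds below may be only part of what the source reports. "The series", "measured", "known", "first", "only" and "open" are said of these compounds alone.

Compound 2 `CCC(Sc1nc2c(cnn2C)c(=O)n1-c1ccccc1)c1ccccc1` is the starting point. In an assay on isolated protein for inhibition of Retinaldehyde dehydrogenase 3 (Homo sapiens) (on this read-out lower numbers stand for stronger inhibition and higher numbers for weaker inhibition), compound 2 gives 119 nM. Among the measured compounds shown here, the only other measured compound is compound 1 `CC(C)C(Sc1nc2c(cnn2C)c(=O)n1-c1ccccc1)c1ccccc1`, which in this assay gives 130 nM; the two values lie within the scatter of each other, so neither compound can be called the stronger inhibitor. The step of a 1.1-fold lower number from compound 1 to compound 2 (0.04 log units; within the scatter) takes one carbon away from the branched chain and leaves the number essentially unchanged.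

Compound 3 `C[C@H](Sc1nc2c(cnn2C)c(=O)n1-c1ccccc1)c1ccccc1` continues in the same direction: 1-phenylethyl in place of 1-phenylpropyl on a sulfur. This again shortens the same chain by one carbon, now with a defined stereocentre. For the measured compounds named here, the single measured step that bears on this change is the one from compound 1 to compound 2, and it stayed within the scatter. On that basis the expected movement is small, a 1.0-fold lower number from compound 2 to compound 3 (0.01 log units; within the scatter), with no clear direction. Compound 3 is therefore estimated to give 115 nM in this assay, with a range from 50 nM to 260 nM.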

Compound 3, half-maximal inhibitory concentration: 1640 nM
Beside the measured number, compound 3's estimate is 14-fold (1.15 log units) below it; measured number outside the range, above it.
By their numbers in this assay, from the lowest: compounds 2 and 1 (each within the scatter of the next); then compound 3.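

In this assay, the group on the sulfur proves far from indifferent to chain length: 1-phenylethyl in place of 1-phenylpropyl gives a 14-fold higher number from compound 2 to compound 3 (1.14 log units; beyond the scatter) as a large loss of inhibition, whereas the earlier change, a 1.1-fold lower number from compound 1 to compound 2 (0.04 log units; within the scatter) and within the scatter, gave no readable difference. The flat first step therefore did not predict the second, and the tolerance seen between the two earlier compounds does not extend to the shorter 1-phenylethyl group. Compound 3 also brings a defined stereocentre, so the shortening and the fixed arrangement arrive together in this step, and nothing available here explains the loss.

The compounds shown leave open how much of the loss belongs to the stereocentre and how much to the shorter chain, a question that the mirror-image form of compound 3 would address. They also leave open whether a longer chain such as 1-phenylbutyl, or an amine or a hydroxyl group on the chain, would keep or improve the inhibition seen with 1-phenylpropyl.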